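Trimming the Amide of a Weak Bcl-2 Binder

The source may report more compounds than this note shows. Statements on the series, on what has been measured and on what is new or still open speak of the compounds shown alone.

Of the compounds shown here, three built on the shared core have been tested in an assay on isolated protein for inhibition of Apoptosis regulator Bcl-2 (Homo sapiens), read by fluorescence polarization, with stated times of 5 min and 10 min; on this read-out lower numbers stand for stronger inhibition and higher numbers for weaker inhibition. Compound 1 `COc1ccc(NC(=O)[C@@H]2CC=C(CCC=C(C)C)C[C@H]2c2ccccc2)cc1` carries a (4-methoxyphenyl)amino group on its carbonyl. In this assay compound 1 gives > 23000 nM, which is a limit of the assay and not a number. Compound 2 `CON(C)C(=O)[C@H]1CC2=C(CCCC2(C)C)C[C@@H]1c1ccccc1` has a methoxy(methyl)amino group on the carbonyl carbon. In this assay compound 2 gives > 23000 nM, again only a limit. Compound 3 `CC1(C)CCCC2=C1C[C@H](C(=O)O)[C@@H](c1ccccc1)C2` is the free acid. In this assay compound 3 gives > 23000 nM, also a limit. Among the compounds with values here, the one step that changes a single place, a step that the two limits leave unreadable from compound 2 to compound 3, cannot be read because the limit of > 23000 nM in this assay, at which 3 of the 3 values shown sit, hides both of its ends.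

Compound 4 `CC(C)=CCCC1=CC[C@@H](C(N)=O)[C@H](c2ccccc2)C1` is compound 1 with hydrogen in place of 4-methoxyphenyl on an amide-type nitrogen. Within the data shown here, no measured step touches the amide-type nitrogen itself, so nothing here reports how such a trimming moves binding, and the three measured values all sit at the limit without showing any readable step at all. Compound 4 is therefore expected to remain at or beyond the limit, with an estimate of 35000 nM spanning 10000 nM to 150000 nM. That estimate means a step that the limit leaves unreadable from compound 1 to compound 4, a step expected to stay within the usual scatter.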

Compound 4, inhibition constant: > 23000 nM
Compound 4: a limit, no number (the forecaster's own chance of this, stated with the estimate: 85%); the middle value does not contradict the limit.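

Compound 4 gives only a limit of the assay and not a number, just as compound 1 does, so the trimming from compound 1 to compound 4 yields no readable step, because both ends are hidden: the limit of > 23000 nM in this assay, at which 4 of the 4 values shown sit.

The compounds shown leave open whether any change to the shared core can bring a readable number in this assay at all.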